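The source may hold more compounds than are shown below. What is called first, only, known or untested is meant among the compounds shown, and "the series" means these compounds.

Measured so far:
Compound 1 `CN(C)CCn1cnnc1-c1cc(Oc2ccc(NC(=O)N/N=C/c3ccc(F)cc3F)cc2F)ccn1` gives 960 nM in a functional assay on HT-29 cells (Homo sapiens) for cytotoxicity, read by MTT assay, with a stated time of 72 h; a higher number here means a weaker inhibitor, a lower number a stronger inhibitor.
Compound 2 `CN(C)CCn1cnnc1-c1cc(Oc2ccc(NC(=O)N/N=C/c3ccc(O)c(O)c3)cc2F)ccn1` gives 1890 nM in this assay.
Compound 3 `CN(C)CCn1cnnc1-c1cc(Oc2ccc(NC(=O)N/N=C/c3cccc(Br)c3)cc2F)ccn1` gives 380 nM in this assay.

Compound 3 has the lowest number of the three, with a 2.5-fold lower number from compound 1 to compound 3 (0.40 log units; beyond the scatter) and a 5.0-fold lower number from compound 2 to compound 3 (0.70 log units; beyond the scatter) both beyond the scatter. Compound 4 `Cc1cc(/C=N/NC(=O)Nc2ccc(Oc3ccnc(-c4nncn4CCN(C)C)c3)c(F)c2)cc(C)c1O` differs from compound 3 in one place: 4-hydroxy-3,5-dimethylphenyl in place of 3-bromophenyl on a carbon with a double bond to nitrogen. The step that bears most on this is a 5.0-fold lower number from compound 2 to compound 3 (0.70 log units; beyond the scatter), where a hydroxyl-bearing ring in place of the bromophenyl went with a higher number; a 2.5-fold lower number from compound 1 to compound 3 (0.40 log units; beyond the scatter) points the same way. A modest rise in the number is therefore expected for compound 4, within this assay. The estimated step is a 2.6-fold higher number from compound 3 to compound 4 (0.42 log units; beyond the scatter). For compound 4 the expected value is 1000 nM, with a likely range from 400 nM to 2500 nM.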

Compound 4, half-maximal inhibitory concentration: 1220 nM
Compound 4: the middle estimate sits 1.2-fold (0.09 log units) below what was measured, within the range that was stated.
By their numbers in this assay, from the lowest: compound 3; then compounds 1, 4 and 2 (each within the scatter of the next).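

In this assay, 4-hydroxy-3,5-dimethylphenyl on this carbon costs activity against 3-bromophenyl (a 3.2-fold higher number from compound 3 to compound 4 (0.51 log units; beyond the scatter)), so compound 3 now stands clear of all three other rings. Those three cannot be told apart (a 1.5-fold lower number from compound 2 to compound 4 (0.19 log units; within the scatter); a 1.3-fold higher number from compound 1 to compound 4 (0.10 log units; within the scatter)), although compound 1 carries no hydroxyl, so a hydroxyl is not what separates them from compound 3. Nothing measured here gives a reason for the edge of 3-bromophenyl. Still open, going by these compounds, is how a ring bearing an amine or a carboxylic acid would fare on this carbon, and whether chlorine could replace the bromine.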